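The source may report more compounds than this note shows. Statements on the series, on what has been measured and on what is new or still open speak of the compounds shown alone.

Measured compounds:
Compound 1, `COc1cc(/C=C/C(=O)C2=C(/C=C/c3ccc(O)c(OC)c3)NC(=O)NC2c2ccccc2Cl)ccc1O`, gives 23% in a functional assay, with a stated time of 20 min, tested at 10 uM; a higher number here means a stronger effect of the compound at the concentration tested, a lower number a weaker effect.
Compound 2, `COc1cc(/C=C/C(=O)C2=C(/C=C/c3ccc(O)c(OC)c3)NC(=S)NC2c2ccccc2)ccc1O`, gives 22% in this assay.

Going by the values given here, only two compounds have numbers so far, and they stand close together. Compound 2, with its 22%, lies within the scatter of compound 1, so the two cannot be told apart on these numbers; neither can be called the stronger or the weaker. Compound 1 and compound 2 differ in more than one place, so no single step can be read between them.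

Compound 3, `COc1cc(/C=C/C(=O)C2=C(/C=C/c3ccc(O)c(OC)c3)NC(=S)NC2c2ccc(C)cc2)ccc1O`, has not yet been measured. It differs from compound 2 in one place: methyl in place of hydrogen on an aromatic carbon. Among the compounds with values here, nothing among the measured compounds shows what such a change does in this assay, so the expectation rests only on the closeness of compound 1 and compound 2 and on the small size of the group that enters. The step from compound 2 to compound 3 is expected to be small, most likely none beyond the scatter, as a number 3 percentage points higher from compound 2 to compound 3 (within the scatter). For compound 3 the estimate in this assay is 25%, with a range from 12% to 40%.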

Compound 3, a percentage reported as activity, at one concentration (the size of the read-out at that concentration, not a potency): 19.9%
Estimate against measurement, compound 3: 5.1 percentage points above; measured number inside the range.
By their numbers in this assay, from the lowest: compounds 3, 2 and 1 (each within the scatter of the next).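

In this assay, going by these compounds alone, methyl in place of hydrogen on an aromatic carbon, para to a large group, gives a number 2.1 percentage points lower from compound 2 to compound 3 (within the scatter), and this is the first step that can be read at a single place. It shows that, at the one concentration tested, the change from phenyl to 4-methylphenyl leaves compound 3 indistinguishable from compound 2, so this position accepts a group of 1 heavy atom without a read-out that can be told apart. No measurement at hand bears on why this is so.

As far as these compounds go, whether a different group at this position, such as an amine, a carboxylic acid or a longer chain, would carry the read-out beyond the scatter remains open. From the compounds shown here alone, it is also open whether methyl on another carbon of this ring would behave in the same way, and the single concentration says nothing about potency.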